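Sec-butyl for isobutyl on a phenylsulfonyl core

The source may report more compounds than this note shows. Statements on the series, on what has been measured and on what is new or still open speak of the compounds shown alone.

The study tests three acylaminoacyl anilides in a functional assay for inhibition, read by spectrophotometry, with a stated time of 20 min, tested at 3 mg/mL; on this read-out higher numbers stand for a stronger effect at the one concentration tested and lower numbers for a weaker effect. Compound 1 `CC(=O)c1ccc(NC(=O)C(CC(C)C)N(C(=O)c2ccccc2)S(=O)(=O)c2ccc([N+](=O)[O-])cc2)cc1` gives 62.3%, compound 2 `CCC(C)C(C(=O)Nc1ccc(C(C)=O)cc1)N(C(=O)c1ccccc1)S(=O)(=O)c1ccc([N+](=O)[O-])cc1` gives 42.1%, and compound 3 `CC(=O)c1ccc(NC(=O)C(CC(C)C)N(C(=O)c2ccccc2)S(=O)(=O)c2ccccc2)cc1` gives 40.7%.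

Two single changes start from compound 1. The first, (sec-butyl in place of isobutyl on a saturated chain carbon bound to an amide-type nitrogen and a carbonyl carbon), gives a number 20.2 percentage points lower from compound 1 to compound 2 (beyond the scatter). The second, (hydrogen in place of nitro on an aromatic carbon), gives a number 21.6 percentage points lower from compound 1 to compound 3 (beyond the scatter). Compound 2 and compound 3 lie within the scatter of each other.

Compound 4 `CCC(C)C(C(=O)Nc1ccc(C(C)=O)cc1)N(C(=O)c1ccccc1)S(=O)(=O)c1ccccc1` is not yet measured. It differs from compound 3 by sec-butyl in place of isobutyl on a saturated chain carbon bound to an amide-type nitrogen and a carbonyl carbon, the same change already seen from compound 1 to compound 2, at the same place. The cores of compound 3 and compound 1 differ by hydrogen in place of nitro on an aromatic carbon.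

On the core of compound 3 this change is expected to give a number 18.7 percentage points lower from compound 3 to compound 4 (beyond the scatter), since it gave a number 20.2 percentage points lower from compound 1 to compound 2 (beyond the scatter) on the other core. This rests on a single earlier step. Compound 4 is therefore estimated at 22%, expected between 5% and 40%.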

Compound 4, a percentage reported as inhibition, at one concentration (the size of the read-out at that concentration, not a potency): 14.3%
Compound 4: middle estimate off by 7.7 percentage points, on the high side; measured number inside the range.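

In this assay, going by these compounds alone, sec-butyl in place of isobutyl on the core of compound 3 gives a number 26.4 percentage points lower from compound 3 to compound 4 (beyond the scatter), and this step agrees with the one seen on the core of compound 1: the same change on two cores in this assay, a number 20.2 percentage points lower (beyond the scatter) from compound 1 to compound 2 and a number 26.4 percentage points lower (beyond the scatter) from compound 3 to compound 4, 6.2 percentage points apart, within the scatter of two such steps Hydrogen in place of nitro, read on the sec-butyl pair, gives a number 27.8 percentage points lower from compound 2 to compound 4 (beyond the scatter), and this step agrees with the one read on the isobutyl pair: the same change on two cores in this assay, a number 21.6 percentage points lower (beyond the scatter) from compound 1 to compound 3 and a number 27.8 percentage points lower (beyond the scatter) from compound 2 to compound 4, 6.2 percentage points apart, within the scatter of two such steps Across these four compounds each change therefore carried over from one core to the other in direction and, within the scatter, in size, but this rests on only two cores that differ by a single group, so it shows neither that the step would hold on a core changed elsewhere nor why either change lowers the number.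

The compounds shown leave open how a straight n-butyl chain or a methyl group would behave on that same saturated chain carbon. They also leave open whether an amine, a nitrile or a chlorine in place of nitro would follow the same additive pattern.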